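A few compounds are considered here, and "the series" means these few. Any claim that something is new, unique, unknown or untested is made for them only; others in the source may bear on it.

Measured so far:
compound 1 `CNc1nc(C#Cc2ccc(Cl)s2)nc2c1ncn2[C@H]1[C@H](O)[C@H](O)[C@]2(C(=O)OC(C)C)C[C@H]12` — 42.9 nM
compound 2 `CNc1nc(C#Cc2ccc(Cl)s2)nc2c1ncn2[C@H]1[C@H](O)[C@H](O)[C@]2(C(=O)OCCC(C)C)C[C@H]12` — 24.4 nM

Both compounds were tested in an assay on HEK-293T cells for displacement of a labelled ligand from transmembrane domain-containing protein TMIGD3 (Homo sapiens), read by scintillation counting and radioligand binding, with stated times of 10 min and 90 min; on this read-out lower numbers stand for stronger inhibition and higher numbers for weaker inhibition. Compound 2 gives the lowest of the two numbers; its nearest neighbour is compound 1, and the step of a 1.8-fold lower number from compound 1 to compound 2 (0.25 log units; within the scatter) shows that the two lie within the scatter of each other, so no order between them can be claimed. Compound 3 `CNc1nc(C#Cc2ccc(Cl)s2)nc2c1ncn2[C@H]1[C@H](O)[C@H](O)[C@]2(C(=O)OCc3ccccc3)C[C@H]12` has not yet been measured. It differs from compound 2 in one place: phenyl in place of isobutyl on a saturated chain carbon bound to an oxygen next to a carbonyl group. Among the compounds with values here, the only measured step that touches this part of the molecule is the exchange of the ester alkyl group between compound 1 and compound 2, which gave a 1.8-fold lower number from compound 1 to compound 2 (0.25 log units; within the scatter). That step did not move the number beyond the scatter, and the new exchange sits at the same oxygen next to the carbonyl group, although a phenyl rather than a longer chain now enters. Within the data shown here, with only this one step to go on, compound 3 is expected to sit near compound 2, with a step of a 1.1-fold higher number from compound 2 to compound 3 (0.03 log units; within the scatter) and no change beyond the scatter. The estimate for compound 3 in this assay is 26 nM, with a range from 10 nM to 65 nM.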

Compound 3, inhibition constant: 7.31 nM
Compound 3: middle estimate off by 3.6-fold (0.55 log units), on the high side, and the stated range ends above it.
By their numbers in this assay, from the lowest: compound 3; then compounds 2 and 1 (each within the scatter of the next).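

In this assay the group on the oxygen next to the carbonyl group now proves able to move the number beyond the scatter: benzyl in place of isopentyl gives a 3.3-fold lower number from compound 2 to compound 3 (0.52 log units; beyond the scatter), and benzyl in place of isopropyl gives a 5.9-fold lower number from compound 1 to compound 3 (0.77 log units; beyond the scatter). The two alkyl esters stay within the scatter of each other, so the earlier exchange showed no effect of this position, whereas among these three compounds only the exchanges that bring in the phenyl ring give steps beyond the scatter, and compound 3 is the strongest of the three in this read-out. Nothing available explains why the benzyl ester stands apart from the isopropyl and isopentyl esters.

Whether the phenyl ring alone carries this step stays open, as the compounds shown include no phenethyl ester, no phenyl ring bearing a chlorine or a methoxy group, and no pyridine ring in its place. They also leave open whether an amide in place of the ester would keep the number this low, and whether the benzyl step would hold with a different group on the shared core.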